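This account rests on a few compounds, and the source may have more. Where it says the series, first, only, none or still open, it means among the compounds named here.

Measured so far:
Compound 1, `O=C(COc1cccc2ccccc12)N/N=C/c1ccc(O)cc1`, in an ADME assay on HEL cells (Homo sapiens) for cytotoxicity (a lower number here means that less compound is tolerated, a higher number that more compound is tolerated), gives 60.6 ug/mL.
Compound 2, `O=C(COc1cccc2ccccc12)N/N=C/c1ccc(Br)cc1`, in this assay gives 100 ug/mL.

Of these two numbers compound 2 has the one that stands higher on paper, but the step of a 1.7-fold higher number from compound 1 to compound 2 (0.22 log units; within the scatter) lies within the scatter, so the two compounds cannot be told apart on this evidence. Compound 3, `O=C(COc1cccc2ccccc12)N/N=C/c1ccc([N+](=O)[O-])cc1`, keeps the shared core and differs from compound 2 in one place: nitro in place of bromo on an aromatic carbon. For the measured compounds named here, the only measured step at this position, from compound 1 to compound 2, exchanged one group for another on the same aromatic carbon and gave a 1.7-fold higher number from compound 1 to compound 2 (0.22 log units; within the scatter), within the scatter. That step does not involve a nitro group, so it bears on the new change only loosely. With nothing showing a shift at this position, compound 3 is expected to stay close to compound 2, with a step of a 1.3-fold lower number from compound 2 to compound 3 (0.10 log units; within the scatter). The estimate for compound 3 in this assay is 80 ug/mL, within a range from 40 ug/mL to 160 ug/mL.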

Compound 3, half-maximal cytotoxic concentration: 14.2 ug/mL
For compound 3 the middle estimate is 5.6-fold (0.75 log units) above the measured one; measured number below the stated range.
By their numbers in this assay, from the lowest: compound 3; then compounds 1 and 2 (each within the scatter of the next).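

Unlike the earlier pair, which could not be told apart, this position can clearly change the result in this assay: nitro in place of bromo gives (a 7.0-fold lower number from compound 2 to compound 3 (0.85 log units; beyond the scatter)), so less of compound 3 is tolerated. Nitro in place of hydroxy points the same way (a 4.3-fold lower number from compound 1 to compound 3 (0.63 log units; beyond the scatter)), which makes compound 3 the least tolerated of the three and sets nitro apart from both other groups at this aromatic carbon. Nothing available explains why this exchange lowers the number.

As far as these compounds go, whether this drop is peculiar to nitro remains open, since an amine, a nitrile or a carboxylic acid on the same carbon could fall with it or stay with bromo and hydroxy. It is also unknown whether nitro would have the same effect on a different core.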